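A Methyl-Branched Acid on the Core of Compound 2

The source may report more compounds than this note shows. Statements on the series, on what has been measured and on what is new or still open speak of the compounds shown alone.

Compound 1 `CC(C)Nc1ccccc1-c1cc(F)c(OCCCC(=O)O)c(F)c1`: > 100000 nM
Compound 2 `CO[C@H]1C[C@H](Oc2cc(F)c(F)c(-c3cc(F)c(OCCCC(=O)O)c(F)c3)c2)C1`: > 100000 nM

Compound 1 `CC(C)Nc1ccccc1-c1cc(F)c(OCCCC(=O)O)c(F)c1` gives in a functional assay on CHO cells for agonist activity at Free fatty acid receptor 1 (Homo sapiens), read by calcium flux (on this read-out higher numbers stand for an effect only at larger amounts of compound and lower numbers for an effect already at smaller amounts), a reading of > 100000 nM, which is a limit of the assay and not a number. Compound 2 `CO[C@H]1C[C@H](Oc2cc(F)c(F)c(-c3cc(F)c(OCCCC(=O)O)c(F)c3)c2)C1` likewise gives in this assay only > 100000 nM, again a limit rather than a measured value. Where compound 2 stands is therefore known only as a boundary: both values shown sit at the limit of > 100000 nM in this assay, at which 2 of the 2 values shown sit, and no step between measured compounds can be drawn from them.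

Compound 3 `CO[C@H]1C[C@H](Oc2cc(F)c(F)c(-c3cc(F)c(OCCC(C)(C)C(=O)O)c(F)c3)c2)C1` keeps the core of compound 2 and differs in one place: 1-carboxy-1-methylethyl in place of carboxymethyl on a saturated chain carbon, two bonds along the chain from an oxygen on an aromatic ring. For the measured compounds named here, with no measured step available, the expectation rests on compound 2 alone; because compound 2 sits at the limit of > 100000 nM in this assay, at which 2 of the 2 values shown sit, the most likely outcome is that compound 3 is also reported only as a limit, with no step beyond the scatter. Compound 3 is accordingly estimated at 100000 nM, within 20000 nM to 300000 nM, which means an expected step of a number no higher from compound 2 to compound 3 (the limit leaves the size open).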

Compound 3, half-maximal effective concentration: > 100000 nM
Compound 3: no number, only a limit (the forecaster's own chance of this, stated with the estimate: 65%); the middle value sits exactly at the limit.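

In this assay compound 3 gives > 100000 nM, which is a limit of the assay and not a number. Compound 2 sits at the same limit, so no step can be read between compound 2 and compound 3. The compounds shown leave open what 1-carboxy-1-methylethyl in place of carboxymethyl does to the reading, as none of them gives a measured number: the limit of > 100000 nM in this assay, at which 3 of the 3 values shown sit.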